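The source may report more compounds than this note shows. Statements on the series, on what has been measured and on what is new or still open speak of the compounds shown alone.

Compound 1 `COc1ccc(/C=C\c2cc(OC)c(OC)c(OC)c2)cc1OCc1ccc(CN2CC[C@@H](O)C2)cc1` carries the shared core, and in a functional assay on MC-38 cells (Mus musculus) for antiproliferative activity, read by CCK-8 assay, with a stated time of 48 h (on this read-out lower numbers stand for stronger inhibition and higher numbers for weaker inhibition), compound 1 gives 6900 nM. Compound 2 `COc1ccc(/C=C\c2cc(OC)c(OC)c(OC)c2)cc1OCc1ccc(CN2CC[C@@H](C(=O)O)C2)cc1` gives 6300 nM in this assay. Compound 3 `COc1ccc(/C=C\c2cc(OC)c(OC)c(OC)c2)cc1OCc1ccc(CN2CCCCC2C(=O)NCCN)cc1` reaches only a limit of this assay, > 10000 nM. Of the two numbers shown, compound 2 holds the lowest, with compound 1 nearest and within the scatter of it. The step to compound 4 `COc1ccc(/C=C\c2cc(OC)c(OC)c(OC)c2)cc1OCc1ccc(CNCCNC(C)=O)cc1` is (2-acetamidoethyl)amino in place of 3-carboxypyrrolidin-1-yl on a saturated chain carbon bound to an aromatic carbon. For the measured compounds named here, two measured steps bear on this change. The first, a 1.1-fold lower number from compound 1 to compound 2 (0.04 log units; within the scatter), shows that swapping the group on the pyrrolidine ring hardly moves the number. The second, an at least 1.5-fold higher number from compound 2 to compound 3 (0.20 log units; that floor lies within the scatter), shows that placing 2-((2-aminoethyl)carbamoyl)piperidin-1-yl on the saturated chain carbon bound to an aromatic carbon lands at the limit of > 10000 nM in this assay, at which 1 of the 3 values shown sits. Compound 4 trades the five-membered ring for an open chain with a second hydrogen-bond donor, a change unlike either measured step, so the author expects a number near compound 2 or somewhat higher, with a real chance that this assay reports only a limit again. The estimate for compound 4 in this assay is 8500 nM, with a range from 3500 nM to 20000 nM, which amounts to an expected step of a 1.3-fold higher number from compound 2 to compound 4 (0.13 log units; within the scatter).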

Compound 4, half-maximal inhibitory concentration: 1800 nM
The estimate for compound 4 lay 4.7-fold (0.67 log units) above the measured number; the whole stated range lies above it.
By their numbers in this assay, from the lowest: compound 4; then compounds 2 and 1 (each within the scatter of the next). At a limit, above all of these: compound 3.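

In this assay, the position on a saturated chain carbon bound to an aromatic carbon now shows a difference beyond the scatter: replacing 3-carboxypyrrolidin-1-yl with (2-acetamidoethyl)amino gives a 3.5-fold lower number from compound 2 to compound 4 (0.54 log units; beyond the scatter), and replacing 3-hydroxypyrrolidin-1-yl with the same group gives a 3.8-fold lower number from compound 1 to compound 4 (0.58 log units; beyond the scatter). The earlier exchange on the pyrrolidine ring alone gave only a 1.1-fold lower number from compound 1 to compound 2 (0.04 log units; within the scatter), so this position responds to replacing the whole group with the open chain, even though swapping the hydroxy for the carboxy did not register. Against the piperidine compound the step is an at least 5.5-fold lower number from compound 3 to compound 4 (0.74 log units; beyond the scatter), and that size is only a floor, as compound 3 stands at a limit of the assay and not at a number: the limit of > 10000 nM in this assay, at which 1 of the 4 values shown sits.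

The shown compounds leave open whether the gain comes from losing the ring or from gaining the acetamide, as compound 4 changes both in a single step. A free primary amine in place of the acetamide, a longer chain in place of the ethyl link, or an acetamide carried on a pyrrolidine ring would be needed to separate these two changes.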